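The source may report more compounds than this note shows. Statements on the series, on what has been measured and on what is new or still open speak of the compounds shown alone.

Working notes on the series. The shared core of compound 1 `N#Cc1cnc(NCc2cnccc2C(F)(F)F)cc1NC[C@H]1C[C@@H](O)C1` is kept throughout; the substituent on the ring nitrogen is the variable of interest here. In an assay on isolated protein for inhibition of protein kinase C delta type (Homo sapiens), read by TR-FRET, with a stated time of 2 h (on this read-out lower numbers stand for stronger inhibition and higher numbers for weaker inhibition), compound 1 gives 4200 nM, the higher of the two numbers recorded so far. Compound 3 `N#Cc1cnc(NCc2cncnc2-c2ccccc2)cc1N[C@H]1CC[C@@H](O)CC1` gives 90 nM in this assay, a gap from compound 1 that lies well beyond the scatter. Compound 2 `N#Cc1cnc(NCc2ccccc2C(F)(F)F)cc1N[C@H]1CC[C@H](O)CC1` reaches only a limit of this assay, > 10000 nM. Going by the values given here, that limit, (the limit of > 10000 nM in this assay, at which 1 of the 3 values shown sits), is the only other value available, so the spread among the measured set runs from a clearly active compound to one outside the window.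

Compound 4 `CC1(C)C[C@@H](Nc2cc(NCc3cnccc3C(F)(F)F)ncc2C#N)CC[C@H]1O` is not yet measured. Relative to compound 1 the change is 4-hydroxy-3,3-dimethylcyclohexyl in place of (3-hydroxycyclobutyl)methyl on a nitrogen on an aromatic ring. Among the compounds with values here, no pair among the measured compounds isolates this change, so the step from compound 1 is set by expectation alone. A 4-hydroxy-3,3-dimethylcyclohexyl directly on the nitrogen is expected to move the number downward by a moderate margin rather than to leave it flat. For compound 4 the expected value in this assay is 1500 nM, with a range of 300 nM to 6000 nM. The step this implies, a 2.8-fold lower number from compound 1 to compound 4 (0.45 log units; beyond the scatter), is an estimate pending the measurement.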

Compound 4, half-maximal inhibitory concentration: 2400 nM
The estimate for compound 4 lay 1.6-fold (0.20 log units) below the measured number; measured number inside the range.
By their numbers in this assay, from the lowest: compound 3; then compounds 4 and 1 (each within the scatter of the next). At a limit, above all of these: compound 2.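

Working notes, continued. In this assay, 4-hydroxy-3,3-dimethylcyclohexyl in place of (3-hydroxycyclobutyl)methyl on a nitrogen on an aromatic ring gives a 1.8-fold lower number from compound 1 to compound 4 (0.24 log units; within the scatter), so the two compounds cannot be told apart on this read-out. Going by these compounds alone, this is the first reading at this position on the shared core of compound 1, and it shows that a six-membered ring of 9 heavy atoms set directly on the nitrogen and a four-membered ring of 6 heavy atoms in (3-hydroxycyclobutyl)methyl give numbers within the scatter of each other, a finding that rests on this one pair alone. Nothing on record bears on why these two groups read alike, and no cause can be given for the result.

Within the data shown here, compounds 2 and 3 each differ from compound 1 and from compound 4 in more than one place, so no steps to them can be read, and the part played by the two methyl groups on the cyclohexyl ring stays unresolved. Also open, going by these compounds, is how this position responds when the hydroxyl of the ring is replaced by a methoxy group or an amine, or when a carboxylic acid is carried on the ring instead.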